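The compounds below may be only part of what the source reports. "The series", "measured", "known", "first", "only" and "open" are said of these compounds alone.

Values in a functional assay for inhibition, with Homo sapiens as the target; a higher number here means a weaker inhibitor, a lower number a stronger inhibitor:
compound 1 `CCOc1ccccc1C(=O)/C=C/c1ccccc1`: 609 nM
compound 2 `CN(C)C(=O)c1ccccc1C(=O)/C=C/c1ccccc1`: 5500 nM
compound 3 `O=C(/C=C/c1ccccc1)c1ccccc1C(F)(F)F`: 748 nM

Compound 3 at 748 nM cannot be told apart from compound 1 (a 1.2-fold higher number from compound 1 to compound 3 (0.09 log units; within the scatter)) and stands well clear of compound 2 (a 7.4-fold lower number from compound 2 to compound 3 (0.87 log units; beyond the scatter)). The next change leads to compound 4 `CN(C)c1ccccc1C(=O)/C=C/c1ccccc1` with dimethylamino in place of trifluoromethyl on an aromatic carbon.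

For the measured compounds named here, no measured compound carries dimethylamino, so the evidence is indirect. Going by the values given here, two steps bear on this change. Swapping ethoxy for trifluoromethyl made no difference beyond the scatter (a 1.2-fold higher number from compound 1 to compound 3 (0.09 log units; within the scatter)). The only sizeable shift came with dimethylcarbamoyl in compound 2 (a 9.0-fold higher number from compound 1 to compound 2 (0.96 log units; beyond the scatter)), a group that shares the two methyl groups on nitrogen but also holds a carbonyl that dimethylamino lacks. In this assay no step beyond the scatter is therefore expected, with a slight lean towards a higher number, and the upper range is left wide. The expected change is a 1.3-fold higher number from compound 3 to compound 4 (0.13 log units; within the scatter). For compound 4 the estimate is 1000 nM, with an expected range of 350 nM to 3500 nM.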

Compound 4, half-maximal inhibitory concentration: 1770 nM
Estimate against measurement, compound 4: 1.8-fold (0.25 log units) below; measured number inside the range.
By their numbers in this assay, from the lowest: compounds 1 and 3 (each within the scatter of the next); then compound 4; then compound 2.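

In this assay, dimethylamino on this aromatic carbon, ortho to a large group, gives the first separation from both ethoxy (a 2.9-fold higher number from compound 1 to compound 4 (0.46 log units; beyond the scatter)) and trifluoromethyl (a 2.4-fold higher number from compound 3 to compound 4 (0.37 log units; beyond the scatter)), two groups that could not be told apart at this place. Removing the carbonyl from dimethylcarbamoyl while keeping the two methyl groups on nitrogen restores only part of the lost ground (a 3.1-fold lower number from compound 2 to compound 4 (0.49 log units; beyond the scatter)), so the carbonyl does not account for the whole of the rise seen with dimethylcarbamoyl in this small set. Nothing available explains why these groups differ at this position.

On these data alone, whether the nitrogen itself or its two methyl groups drive the rise remains open, and an unsubstituted amine or a methylamino group at the same place would separate the two. A methoxy group, a carboxylic acid or a longer alkoxy chain would show how far the range of this position extends.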